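A few compounds are considered here, and "the series" means these few. Any claim that something is new, unique, unknown or untested is made for them only; others in the source may bear on it.

Series of anilide amides on a shared core, followed in an assay on isolated protein for inhibition of Rho-associated protein kinase 1 (Homo sapiens), read by scintillation counting, radiometric assay and 33P incorporation, with a stated time of 40 min, in the presence of a further agent that is not named here; a higher number here means a weaker inhibitor, a lower number a stronger inhibitor. Compound 1 `O=C(COc1ccc2c(=O)ccoc2c1)Nc1cccc(NC(=O)c2ccccc2)c1` gives 120 nM. Compound 2 `O=C(COc1ccc2c(=O)ccoc2c1)Nc1cccc(NC(=O)c2ccc(F)cc2)c1` gives 129 nM; the step of a 1.1-fold higher number from compound 1 to compound 2 (0.03 log units; within the scatter) lies within the scatter. Among the measured compounds shown here, compound 3 `NCc1ccc(C(=O)Nc2cccc(NC(=O)COc3ccc4c(=O)ccoc4c3)c2)cc1` gives 532 nM, the highest of the three numbers; the steps of a 4.4-fold higher number from compound 1 to compound 3 (0.65 log units; beyond the scatter) and a 4.1-fold higher number from compound 2 to compound 3 (0.62 log units; beyond the scatter) are both beyond the scatter and are the only measured steps that touch the terminal aryl group.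

Compound 4 `Nc1cccc(C(=O)Nc2cccc(NC(=O)COc3ccc4c(=O)ccoc4c3)c2)c1` differs from compound 3 by 3-aminophenyl in place of 4-(aminomethyl)phenyl on a carbonyl carbon. No measured step exchanges one amine-bearing terminal aryl for another; the nearest information is that 4-(aminomethyl)phenyl in compound 3 cost modestly against both phenyl and 4-fluorophenyl, as shown in a 4.4-fold higher number from compound 1 to compound 3 (0.65 log units; beyond the scatter) and a 4.1-fold higher number from compound 2 to compound 3 (0.62 log units; beyond the scatter). Since 3-aminophenyl is a different group from 4-(aminomethyl)phenyl, a number between compound 1 and compound 3 is expected, with a step of a 1.8-fold lower number from compound 3 to compound 4 (0.25 log units; within the scatter) that could still fall within the scatter. The estimate for compound 4 in this assay is 300 nM, with a range from 120 nM to 750 nM.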

Compound 4, half-maximal inhibitory concentration: 670 nM
For compound 4 the middle estimate is 2.2-fold (0.35 log units) below the measured one, within the range that was stated.
By their numbers in this assay, from the lowest: compounds 1 and 2 (each within the scatter of the next); then compounds 3 and 4 (each within the scatter of the next).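

In this assay the two amine-bearing terminal aryl groups cannot be told apart: 3-aminophenyl in place of 4-(aminomethyl)phenyl on the carbonyl carbon leaves the number within the scatter (a 1.3-fold higher number from compound 3 to compound 4 (0.10 log units; within the scatter)). Among the compounds shown here, the modest loss against the amine-free groups appears again with this second amine-bearing group (a 5.6-fold higher number from compound 1 to compound 4 (0.75 log units; beyond the scatter)) and (a 5.2-fold higher number from compound 2 to compound 4 (0.72 log units; beyond the scatter)), both beyond the scatter, and no compound among the four goes against this. Nothing available explains these steps.

The compounds shown leave open whether a different group carrying an amine, such as 4-aminophenyl or 3-(aminomethyl)phenyl, would fall in the same range. They also leave open how a hydroxyl or a carboxylic acid on the terminal phenyl would compare with the amino group of compound 4.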